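Piperidine side-chain variation in the furan amide series

A few compounds are considered here, and "the series" means these few. Any claim that something is new, unique, unknown or untested is made for them only; others in the source may bear on it.

Three compounds carry numbers in a functional assay on OVCAR-8 cells (Homo sapiens) for antiproliferative activity; a lower number here means a stronger inhibitor, a higher number a weaker inhibitor. Compound 1 `Cn1ncc(Cl)c1-c1cc(C(=O)N[C@@H]2CNCC[C@H]2c2ccc(C(F)(F)F)cc2)oc1Cl` gives 120 nM. Compound 2 `Cn1ncc(Cl)c1-c1cc(C(=O)N[C@@H]2CN[C@H](CC(=O)NC3CC3)C[C@H]2c2ccc(Cl)c(Cl)c2)oc1Cl`, which bears a cyclopropylcarbamoyl-bearing chain on the saturated ring and a dichlorophenyl group in place of the trifluoromethylphenyl group, gives 580 nM. Compound 3 `O=C(N[C@@H]1CNCC[C@H]1c1ccc(Cl)cc1)c1ccc(-c2ncnc3c2CCC3O)s1`, built on a different core, gives 24100 nM. Compound 2 thus stands second highest of the three: its nearest neighbour is compound 1, whose lower number lies beyond the usual scatter, and its furthest is compound 3, whose higher number also lies beyond it. Within the data shown here, no two of the measured compounds differ in only one place, so no single step has been isolated.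

Compound 4 `Cn1ncc(Cl)c1-c1cc(C(=O)N[C@@H]2CN[C@H](CCN3CCC(O)CC3)C[C@H]2c2ccc(Cl)c(Cl)c2)oc1Cl` has not been measured. It differs from compound 2 as follows: (4-hydroxypiperidin-1-yl)methyl in place of cyclopropylcarbamoyl on a saturated chain carbon bound to a saturated ring carbon. The shared core, the saturated ring and the dichlorophenyl group are unchanged; only the chain end is exchanged. Nothing in the measured set shows how this chain end alone moves the number, so no direction can be read from the data. The step expected here is a 1.5-fold lower number from compound 2 to compound 4 (0.16 log units; within the scatter), which is not beyond the usual scatter. Compound 4 is therefore estimated at 400 nM, with a range from 120 nM to 1400 nM.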

Compound 4, half-maximal inhibitory concentration: 15900 nM
Beside the measured number, compound 4's estimate is 40-fold (1.60 log units) below it, outside the stated range (above it).
By their numbers in this assay, from the lowest: compound 1; then compound 2; then compounds 4 and 3 (each within the scatter of the next).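

In this assay, among these compounds, exchanging cyclopropylcarbamoyl for (4-hydroxypiperidin-1-yl)methyl on a saturated chain carbon bound to a saturated ring carbon gives a 27-fold higher number from compound 2 to compound 4 (1.44 log units; beyond the scatter), and this is the only step in the set that isolates a single place. The shared core, the saturated ring and the dichlorophenyl group stay fixed, so the number is shown to be highly sensitive to the chain end, which the earlier compounds, all differing in more than one place, could not show. No measured evidence bears on why this exchange costs so much.

The exchange removes the cyclopropyl ring and the carbonyl and brings in a six-membered ring with one hetero atom and a hydroxyl group, and a single step cannot say which of these changes carries the loss. A plain piperidine without the hydroxyl, a morpholine, a dimethylamino group or a carboxylic acid at the same chain end would separate these contributions, and a shorter chain would test whether chain length also plays a part.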